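Fluorine on the phenoxy ring: a small change to compound 3

The compounds below may be only part of what the source reports. "The series", "measured", "known", "first", "only" and "open" are said of these compounds alone.

Going by the values given here, the three compounds measured so far share one core and differ only in the group on a saturated ring carbon. Compound 1 `O=C(O)CC/C=C\CC1COC(c2ccccc2Cl)OC1c1cccnc1` carries a 2-chlorophenyl there and in an assay for inhibition of Thromboxane-A synthase (Homo sapiens), using microsomes (a higher number here means a weaker inhibitor, a lower number a stronger inhibitor), compound 1 gives 48 nM. Compound 2 `O=C(O)CC/C=C\CC1COC(c2ccc3ccccc3c2)OC1c1cccnc1` carries a naphthalen-2-yl and in this assay compound 2 gives 50 nM. Compound 3 `CC(C)(Oc1ccccc1)C1OCC(C/C=C\CCC(=O)O)C(c2cccnc2)O1` carries a phenoxy-bearing group and in this assay compound 3 gives 52 nM, the highest of the three numbers, though its neighbours sit close: a 1.1-fold higher number from compound 1 to compound 3 (0.03 log units; within the scatter) and a 1.0-fold higher number from compound 2 to compound 3 (0.02 log units; within the scatter), just as a 1.0-fold higher number from compound 1 to compound 2 (0.02 log units; within the scatter).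

Compound 4 `CC(C)(Oc1ccc(F)cc1)C1OCC(C/C=C\CCC(=O)O)C(c2cccnc2)O1` differs from compound 3 by fluoro in place of hydrogen on an aromatic carbon. Among the compounds with values here, no measured step adds a fluoro, so none bears on this change directly. What the measured steps do show is that swapping the whole group on that saturated ring carbon, even between quite different shapes, left the number where it was. Adding a single fluorine at the edge of that group is a smaller change still, so no step beyond the scatter is expected, in either direction. Compound 4 is therefore estimated at 50 nM, with a range from 22 nM to 115 nM, meaning an expected 1.0-fold lower number from compound 3 to compound 4 (0.02 log units; within the scatter).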

Compound 4, half-maximal inhibitory concentration: 51 nM
Estimate against measurement, compound 4: 1.0-fold (0.01 log units) below; the range from low to high includes it.
By their numbers in this assay, from the lowest: compounds 1, 2, 4 and 3 (each within the scatter of the next).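

In this assay, the step from phenoxy to 4-fluorophenoxy reads a 1.0-fold lower number from compound 3 to compound 4 (0.01 log units; within the scatter), so compound 3 and compound 4 cannot be told apart. The earlier steps shown here exchanged the whole group on the saturated ring carbon, whereas this one alters a single place inside that group, an aromatic carbon para to a large group, and shows that fluoro can stand in place of hydrogen there with no step beyond the scatter. Nothing given here offers an explanation for this result.

Among the compounds shown, fluoro is the only group other than hydrogen at this place, so it remains open whether something larger there, such as a methoxy group or an amine, would also stay within the scatter. All four compounds also keep the same chain ending in a carboxylic acid, which leaves open how the number would respond if that acid gave way to another group, such as an amide.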